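The compounds below may be only part of what the source reports. "The series", "measured", "known", "first", "only" and "open" are said of these compounds alone.

Compound 1 `COc1cc(C(=O)c2cn(-c3ccccc3)cc2-c2ccccc2Cl)cc(OC)c1OC` was tested in a functional assay on MCF7 cells (Homo sapiens) for cytotoxicity, read by MTT assay, with a stated time of 96 h (a higher number here means a weaker inhibitor, a lower number a stronger inhibitor), where compound 1 gave 76 nM. Compound 2 `COc1cc(C(=O)c2cn(-c3ccccc3)cc2-c2ccccc2[N+](=O)[O-])cc(OC)c1OC` differs from compound 1 by nitro in place of chloro on an aromatic carbon, and in this assay compound 2 gave 49 nM, a step of a 1.6-fold lower number from compound 1 to compound 2 (0.19 log units; within the scatter). Compound 3 `COc1cc(C(=O)c2cn(-c3ccc(F)cc3)cc2-c2ccccc2Cl)cc(OC)c1OC` shares the core of compound 1 but carries a change counted as fluoro in place of hydrogen on an aromatic carbon, and in this assay compound 3 gave 83 nM, a step of a 1.1-fold higher number from compound 1 to compound 3 (0.04 log units; within the scatter). All three numbers thus lie within the scatter of one another, and no one of them can be called stronger or weaker than the others.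

Compound 4 `COc1cc(C(=O)c2cn(-c3ccc(F)cc3)cc2-c2ccccc2[N+](=O)[O-])cc(OC)c1OC` has not yet been measured. It stands to compound 3 exactly as compound 2 stands to compound 1: the difference is nitro in place of chloro on an aromatic carbon, and the place of the change is described in the same words for both pairs, so this is the same change, made twice among the four compounds. Within the data shown here, its only measured instance is a 1.6-fold lower number from compound 1 to compound 2 (0.19 log units; within the scatter), a step that stayed within the scatter. Among the measured compounds shown here, a step of about the same size is expected from compound 3 to compound 4 in this assay, namely a 1.6-fold lower number from compound 3 to compound 4 (0.20 log units; within the scatter), because the measured step of a 1.6-fold lower number from compound 1 to compound 2 (0.19 log units; within the scatter) is the sole guide available here. Accordingly, in this assay compound 4 is estimated at 52 nM, with an expected range from 30 nM to 90 nM.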

Compound 4, half-maximal inhibitory concentration: 38 nM
Compound 4: the middle estimate sits 1.4-fold (0.14 log units) above what was measured, and the stated range covers the measured number.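

In this assay, nitro in place of chloro gave a 2.2-fold lower number from compound 3 to compound 4 (0.34 log units; beyond the scatter), the only step among the compounds shown that lies beyond the scatter, yet it does not differ from the same change on the core of compound 1: the same change on two cores in this assay, a 1.6-fold lower number (0.19 log units; within the scatter) from compound 1 to compound 2 and a 2.2-fold lower number (0.34 log units; beyond the scatter) from compound 3 to compound 4, 1.4-fold (0.15 log units) apart, within the scatter of two such steps. Fluoro in place of hydrogen gave a 1.3-fold lower number from compound 2 to compound 4 (0.11 log units; within the scatter), which also agrees with its earlier counterpart: the same change on two cores in this assay, a 1.1-fold higher number (0.04 log units; within the scatter) from compound 1 to compound 3 and a 1.3-fold lower number (0.11 log units; within the scatter) from compound 2 to compound 4, 1.4-fold (0.15 log units) apart, within the scatter of two such steps. Both changes therefore carried across these two cores without a detectable dependence on the core, but this rests on one pair of steps for each change and does not show that nitro gives a larger step on one core than on the other, nor that the agreement would extend to any further core.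

The compounds shown leave open whether the same carrying over would hold for other groups on the 2-substituted phenyl, such as an amine or a nitrile in place of the nitro, or for a chloro or a methyl in place of the fluoro. On these data alone, whether the steps would also hold in another cell line remains open as well.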